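The compounds below may be only part of what the source reports. "The series", "measured", "known", "first", "only" and "open" are said of these compounds alone.

Measured in a functional assay on PC-3 cells (Homo sapiens) for antiproliferative activity, with a stated time of 48 h; on this read-out higher numbers stand for weaker inhibition and lower numbers for stronger inhibition:

- Compound 1 `CC(=O)c1ccc(-c2ccc(N3CCCC3)nn2)cc1`: > 25000 nM
- Compound 2 `CCN(CC)c1ccc(-c2cccc(C(F)(F)F)c2)nn1`: > 25000 nM
- Compound 3 `CCN(CC)c1ccc(-c2ccc(C#N)cc2)nn1`: > 25000 nM

None of these three results is an exact number. In this assay compound 3 gives > 25000 nM, which is a limit of the assay. Among the measured compounds shown here, it shares that position with the other two compounds, as the limit of > 25000 nM in this assay, at which 3 of the 3 values shown sit, shows, so the data contain no exact value to compare against and no measured step between compounds.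

Compound 4 `CCN(CC)c1ccc(-c2ccc(C(C)=O)cc2)nn1` keeps the structure of compound 3 except for one group: acetyl in place of cyano on an aromatic carbon, para to a large group (acetyl in place of cyano on an aromatic carbon).

The closest guide to this change is compound 1, which also carries an acetyl and gives > 25000 nM, again a limit. An acetyl on its own therefore gives no reason to expect stronger inhibition. No step beyond the scatter is expected in this assay, and the estimate is a step that the limit leaves unreadable from compound 3 to compound 4. Compound 4 is expected to most likely reach the same limit, with an estimated value of 30000 nM and an expected range from 12000 nM to 60000 nM.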

Compound 4, half-maximal inhibitory concentration: > 25000 nM
Compound 4 gave a limit, no number; the forecaster's own chance of this, stated with the estimate: 85%; the middle value lies beyond the limit too.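

Compound 4 gives > 25000 nM in this assay, which is a limit and not a number, so neither step, from compound 3 or from compound 1 to compound 4, can be read: the limit of > 25000 nM in this assay, at which 4 of the 4 values shown sit.

The compounds shown leave open which changes to the shared core, if any, would give an exact value in this assay.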